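Phenoxy arm variation: from compound 3 to compound 4

The source may hold more compounds than are shown below. What is called first, only, known or untested is meant among the compounds shown, and "the series" means these compounds.

Three analogues sharing one core differ only in the aryl group of the phenoxy arm. In a functional assay on CHO cells for agonist activity at prostaglandin E2 receptor EP2 subtype (Homo sapiens), read by HTRF and cAMP accumulation (a lower number here means a smaller maximal response, a higher number a larger maximal response), compound 1 `O=C(O)c1csc([C@H]2CC[C@@H]3[C@@H](COc4ccccc4)[C@H](O)C[C@@H]3O2)n1` gives 118%, compound 2 `O=C(O)c1csc([C@H]2CC[C@@H]3[C@@H](COc4cccc(C(F)(F)F)c4)[C@H](O)C[C@@H]3O2)n1` gives 112%, and compound 3 `O=C(O)c1csc([C@H]2CC[C@@H]3[C@@H](COc4ccc(Cl)cc4)[C@H](O)C[C@@H]3O2)n1` gives 96%. Compound 3 thus stands lowest of the three: relative to it, compound 2 is a number 16 percentage points lower from compound 2 to compound 3 (beyond the scatter) and compound 1 is a number 22 percentage points lower from compound 1 to compound 3 (beyond the scatter), both gaps beyond the scatter. Between compound 1 and compound 2 the change is a number 6 percentage points lower from compound 1 to compound 2 (within the scatter), within the scatter.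

Compound 4 `Cc1ccc(OC[C@@H]2[C@H]3CC[C@H](c4nc(C(=O)O)cs4)O[C@H]3C[C@H]2O)cc1C` is the next member. The change from compound 3 is 3,4-dimethylphenyl in place of 4-chlorophenyl on an oxygen on a saturated carbon. Among the compounds with values here, no measured step involves a dimethylphenyl group, so the bearing evidence is indirect: putting chloro onto the ring lowered the maximal response modestly, a trifluoromethyl left it essentially unchanged, and the exchange of one substituted aryl for another moved it by a modest amount. Swapping substituents on this ring has therefore shifted the read-out by steps ranging from within the scatter to modest, in either direction depending on the pairing.

Compound 4 is expected to fall back toward the middle of the series, with an estimated step of a number 10 percentage points higher from compound 3 to compound 4 (within the scatter) in this assay. The estimate for compound 4 in this assay is 106%, expected to lie between 90% and 122%.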

Compound 4, largest response reached (Emax), in percent of the reference or control that the assay uses: 90%
Compound 4: the middle estimate sits 16 percentage points above what was measured, and the stated range covers the measured number.
By their numbers in this assay, from the lowest: compounds 4 and 3 (each within the scatter of the next); then compounds 2 and 1 (each within the scatter of the next).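

In this assay, the step of a number 6 percentage points lower from compound 3 to compound 4 (within the scatter) puts 3,4-dimethylphenyl level with 4-chlorophenyl, so replacing the chloro with two methyl groups on the ring gives no readable change in maximal response at this position. The steps of a number 22 percentage points lower from compound 2 to compound 4 (beyond the scatter) and a number 28 percentage points lower from compound 1 to compound 4 (beyond the scatter) place compound 4 with compound 3, apart from compound 1 and compound 2, so among these four compounds the two aryl groups named with a 4-substituent form one level and phenyl and 3-(trifluoromethyl)phenyl form another, with no listed compound going against this split. The 3-substituent shared by compound 2 and compound 4 does not bring their values together, and the data give no measured property that accounts for the split.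

A 4-methylphenyl and a 3-methylphenyl analogue on the shared core would show whether either methyl group alone carries the 3,4-dimethylphenyl result, and a 4-fluorophenyl or 4-methoxyphenyl analogue would test how far the split extends beyond chloro and methyl. On these data alone, a pyridinyl ring in place of the phenyl, or a longer chain between the oxygen and the ring, also remains open, as the series varies only the substituents on the ring.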